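This account rests on a few compounds, and the source may have more. Where it says the series, first, only, none or still open, it means among the compounds named here.

Measured compounds in a functional assay on SK-MEL-2 cells (Homo sapiens) for inhibition, read by sulforhodamine B assay, with a stated time of 48 h, tested at 10 uM; on this read-out higher numbers stand for a weaker effect at the one concentration tested and lower numbers for a stronger effect:
- compound 1 `COc1cc2cc(Oc3ccc(NC(=O)Nc4ccc(C)cc4)cc3)c(C)nc2cc1OC`: compound 1 gives 91.5%
- compound 2 `COc1cc2cc(Oc3ccc(NC(=O)Nc4ccc(C(F)(F)F)cc4)cc3)c(C)nc2cc1OC`: compound 2 gives 76.7%
- compound 3 `COc1cc2cc(Oc3ccc(NC(=O)Nc4cccc(C(F)(F)F)c4)cc3)c(C)nc2cc1OC`: compound 3 gives -35.8%

Compound 3 holds the lowest number of the three, separated from the others by steps beyond the scatter: a number 112.5 percentage points lower from compound 2 to compound 3 (beyond the scatter) and a number 127.3 percentage points lower from compound 1 to compound 3 (beyond the scatter). The step of a number 14.8 percentage points lower from compound 1 to compound 2 (beyond the scatter) is modest by comparison. Compound 4 `COc1cc2cc(Oc3ccc(NC(=O)Nc4ccc(Cl)c(C(F)(F)F)c4)cc3)c(C)nc2cc1OC` differs from compound 3 by chloro in place of hydrogen on an aromatic carbon. Among the compounds with values here, none of the measured steps adds a chloro; the measured steps only show that a 3-(trifluoromethyl)phenyl group sits far lower than either 4-substituted phenyl group, and compound 4 keeps that 3-(trifluoromethyl)phenyl arrangement. The expected step of a number 4.2 percentage points lower from compound 3 to compound 4 (within the scatter) in this assay is therefore small, with no clear direction and likely within the scatter, since the only bearing is that the low-lying group is retained. Compound 4 is accordingly expected to give -40%, with a range from -85% to 25%.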

Compound 4, a percentage reported as activity, at one concentration (the size of the read-out at that concentration, not a potency): -49.8%
Beside the measured number, compound 4's estimate is 9.8 percentage points above it; the range from low to high includes it.
By their numbers in this assay, from the lowest: compound 4; then compound 3; then compound 2; then compound 1.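

In this assay, chloro on the aromatic carbon ortho to the trifluoromethyl group and para to a large group takes the number further down, a number 14 percentage points lower from compound 3 to compound 4 (beyond the scatter), a modest step that shows this carbon can carry a substituent without losing the low reading of the 3-(trifluoromethyl)phenyl compound. The 4-chloro-3-(trifluoromethyl)phenyl group also stands far from both groups lacking a substituent at the 3-position, with a number 126.5 percentage points lower from compound 2 to compound 4 (beyond the scatter) and a number 141.3 percentage points lower from compound 1 to compound 4 (beyond the scatter), so a 4-substituent is tolerated here when the 3-trifluoromethyl group is present. Nothing available explains the chloro step.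

Open, as far as these compounds go, is whether fluoro, a methoxy group or an amine on the same carbon would give a similar step. Also open, from the compounds shown here alone, is whether chloro would lower the number without the neighbouring trifluoromethyl group.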